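This account rests on a few compounds, and the source may have more. Where it says the series, first, only, none or still open, it means among the compounds named here.

In an assay on isolated protein for inhibition of Polyunsaturated fatty acid 5-lipoxygenase (Homo sapiens), read by ELISA, with a stated time of 10 min (on this read-out lower numbers stand for stronger inhibition and higher numbers for weaker inhibition), compound 1 `CCCCCCCCCCCCCCCc1cc(O)cc(OC)c1O` gives 140 nM. Compound 2 `CCCCCCCCCCCc1cc(O)cc(OC)c1O` gives 280 nM in this assay and stands at the top of the two numbers, though its gap to compound 1 is within the scatter. Among the compounds with values here, the only measured step that bears on the question is a 2.0-fold higher number from compound 1 to compound 2 (0.30 log units; within the scatter). Compound 3 `CCCCCCCCCCCCCc1cc(O)cc(OC)c1O` differs from compound 2 by ethyl in place of hydrogen on a saturated chain carbon, ten or more bonds along the chain from an aromatic carbon. Because a 2.0-fold higher number from compound 1 to compound 2 (0.30 log units; within the scatter) lay within the scatter, the expected step is a 1.4-fold lower number from compound 2 to compound 3 (0.15 log units; within the scatter), none beyond the scatter, if anything toward a lower number. Compound 3 is therefore estimated at 200 nM, within a range of 90 nM to 450 nM.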

Compound 3, half-maximal inhibitory concentration: 1490 nM
For compound 3 the middle estimate is 7.5-fold (0.87 log units) below the measured one; measured number outside the range, above it.
By their numbers in this assay, from the lowest: compounds 1 and 2 (each within the scatter of the next); then compound 3.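

Ethyl in place of hydrogen at this saturated chain carbon is not the small change the earlier pair suggested: it gives a 5.3-fold higher number from compound 2 to compound 3 (0.73 log units; beyond the scatter), and the comparison with the longest chain shows an 11-fold higher number from compound 1 to compound 3 (1.03 log units; beyond the scatter). The number therefore does not follow chain length steadily, since the chains of compound 1 and compound 2 lie on either side of that of compound 3, yet those two stay within the scatter of each other. Nothing measured here accounts for this. As far as these compounds go, it remains open how a still longer chain would read, and whether an amine or a carboxylic acid on this chain would change the picture.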